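A few compounds are considered here, and "the series" means these few. Any claim that something is new, unique, unknown or untested is made for them only; others in the source may bear on it.

Measured compounds:
compound 1 `C=CCn1c(=O)n(C2C=CC(CO)O2)c2nc(N)nc(O)c21`: 89%
compound 2 `Nc1nc(O)c2c(n1)n(C1OC(CO)[C@@H](O)[C@H]1O)c(=O)n2Cc1ccc([N+](=O)[O-])cc1`: 50%
compound 3 `CCCn1c(=O)n(C2C=CC(CO)O2)c2nc(N)nc(O)c21`: 102%

All three numbers come from a functional assay on YAC-1 cells (Mus musculus); on this read-out higher numbers stand for larger maximal responses and lower numbers for smaller maximal responses. Compound 1 stands second highest of the three; the nearest number is that of compound 3, a number 13 percentage points higher from compound 1 to compound 3 (beyond the scatter), and the furthest is compound 2, whose value lies well below that of compound 1.

The step now followed goes from compound 1 to compound 4 `C=CCn1c(=O)n(CCCC)c2nc(N)nc(O)c21`. The change is a group of 4 heavy atoms (4 carbon; no ring) in place of a group of 7 heavy atoms (5 carbon, 2 oxygen; one five-membered non-aromatic ring with 1 hetero atom), on an aromatic nitrogen.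

Among the compounds with values here, only one measured step exists in the set, the one from compound 1 to compound 3, and it sits on the other ring nitrogen, where ethyl replaces vinyl; it is modest, a number 13 percentage points higher from compound 1 to compound 3 (beyond the scatter). Within the data shown here, no measured pair exchanges the ring-bearing group on the aromatic nitrogen for an open chain, so nothing in this assay speaks directly to the present change. Compound 2, which carries a different ring on that nitrogen together with a different group on the other nitrogen, differs from compound 1 in two places and gives no clean reading either.

Among the measured compounds shown here, with no direct precedent, the expectation for compound 4 is a step of a number 7 percentage points lower from compound 1 to compound 4 (within the scatter), which may well fall within the scatter, with a wide range to allow for a loss. The estimated value for compound 4 is 82%, between 55% and 105%.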

Compound 4, largest response reached (reported as maximal response), in percent of the reference or control that the assay uses: 21%
The estimate for compound 4 lay 61 percentage points above the measured number; measured number outside the range, below it.
By their numbers in this assay, from the lowest: compound 4; then compound 2; then compound 1; then compound 3.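

In this assay the group on this aromatic nitrogen proves decisive for the size of the response: butyl in place of the group with one five-membered non-aromatic ring with 1 hetero atom gives a number 68 percentage points lower from compound 1 to compound 4 (beyond the scatter). Within the data shown here, this step is far larger than the only earlier step on the shared core, a number 13 percentage points higher from compound 1 to compound 3 (beyond the scatter), which concerns the allyl group, so with allyl kept in place, an open butyl chain does not stand in for the ring-bearing group at this position. No measurement on hand accounts for the size of this step.

From the compounds shown here alone, it remains open which feature of the departing group matters, whether the ring, its double bond, or its hydrogen-bond donor and acceptors, and a butyl chain ending in a hydroxyl group, or one ending in an amine or a carboxylic acid, would help to separate these. Going by these compounds, it is also open whether the step from the ring-bearing group to butyl keeps its size when a propyl group stands in place of the allyl group.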